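The compounds below may be only part of what the source reports. "The series", "measured", "known", "first", "only" and "open" are said of these compounds alone.

The series shares the core seen in compound 1 `CCOC(=O)C1=C(C)NC(=S)NC1c1cn(-c2ccccc2)nc1-c1ccccc1`, where the carbonyl carbon carries an ethoxy group; in a functional assay on MCF7 cells (Homo sapiens) for inhibition, read by sulforhodamine B assay, with a stated time of 24 h (on this read-out lower numbers stand for stronger inhibition of growth and higher numbers for weaker inhibition of growth), compound 1 gives 42000 nM. Compound 2 `CC1=C(C(=O)Nc2ccccc2)C(c2cn(-c3ccccc3)nc2-c2ccccc2)NC(=S)N1` has anilino on that carbonyl carbon instead and in this assay gives 88200 nM, a step of a 2.1-fold higher number from compound 1 to compound 2 (0.32 log units; beyond the scatter). Compound 3 `CC1=C(C(=O)Nc2ccc(Cl)cc2)C(c2cn(-c3ccccc3)nc2-c2ccccc2)NC(=S)N1` carries (4-chlorophenyl)amino on the carbonyl carbon and in this assay gives 34700 nM; against compound 1 the step is a 1.2-fold lower number from compound 1 to compound 3 (0.08 log units; within the scatter), against compound 2 it is a 2.5-fold lower number from compound 2 to compound 3 (0.41 log units; beyond the scatter). Compound 3 thus holds the lowest number of the three shown, although its gap to compound 1 is within the scatter, so no order between those two is warranted.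

Compound 4 `CC1=C(C(=O)Nc2ccccc2Cl)C(c2cn(-c3ccccc3)nc2-c2ccccc2)NC(=S)N1` differs from compound 3 by 2-chlorophenyl in place of 4-chlorophenyl on an amide-type nitrogen. For the measured compounds named here, the only measured step that touches the chloro is a 2.5-fold lower number from compound 2 to compound 3 (0.41 log units; beyond the scatter), which is modest; nothing measured compares the two placings of chloro on the phenyl, so the direction of moving it is unknown. The expectation in this assay is therefore a 1.4-fold higher number from compound 3 to compound 4 (0.16 log units; within the scatter), not beyond the scatter, with the direction left open. Compound 4 is accordingly estimated at 50000 nM in this assay, with a range from 20000 nM to 125000 nM.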

Compound 4, concentration for 50% growth inhibition: 68800 nM
Beside the measured number, compound 4's estimate is 1.4-fold (0.14 log units) below it; low and high end bracket the measured number.
By their numbers in this assay, from the lowest: compounds 3, 1, 4 and 2 (each within the scatter of the next, the first and the last beyond it).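

For the compounds shown here, the first direct comparison of the two chloro placings on the phenyl in this assay is a step (a 2.0-fold higher number from compound 3 to compound 4 (0.30 log units; within the scatter)) within the scatter, so neither 2-chlorophenyl nor 4-chlorophenyl can be ranked above the other. Chloro in place of hydrogen on an aromatic carbon now has two readings, one beyond the scatter (a 2.5-fold lower number from compound 2 to compound 3 (0.41 log units; beyond the scatter)) and one within it (a 1.3-fold lower number from compound 2 to compound 4 (0.11 log units; within the scatter)), so the modest shift seen earlier with 4-chlorophenyl is not reproduced by 2-chlorophenyl, even though the two chloro compounds themselves stay unresolved. On the carbonyl carbon, (2-chlorophenyl)amino and ethoxy also stay unresolved (a 1.6-fold higher number from compound 1 to compound 4 (0.21 log units; within the scatter)), leaving compounds 1, 3 and 4 without a warranted order.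

No supporting evidence is available to account for any of these readings. Still open, from the compounds shown here alone, is whether methoxy in place of chloro on the phenyl, or a benzylamino or morpholine group on the carbonyl carbon, would move the number beyond the scatter from that of compound 1.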